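Chloro for fluoro on the anilino ring of compound 2

The source may report more compounds than this note shows. Statements on the series, on what has been measured and on what is new or still open speak of the compounds shown alone.

Of the compounds shown here, two have numbers so far. Compound 1 `O=C(/C=C\Nc1ccc(Cl)cc1)c1cn(-c2ccccc2)nc1-c1ccc(F)cc1` carries a chloro-substituted anilino group and a fluoro-substituted aryl on the shared core; in a functional assay on A549 cells (Homo sapiens) for antiproliferative activity, read by MTT assay, with a stated time of 48 h (on this read-out lower numbers stand for stronger inhibition and higher numbers for weaker inhibition), compound 1 gives 6700 nM. Compound 2 `COc1ccc(-c2nn(-c3ccccc3)cc2C(=O)/C=C\Nc2ccc(F)cc2)cc1` carries the fluoro-substituted anilino group and a methoxy-substituted aryl; in this assay compound 2 gives 3980 nM. The two values lie close together, and their separation falls within the scatter of repeated measurements of this kind, so no order between compound 1 and compound 2 can be read from them.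

Compound 3 `COc1ccc(-c2nn(-c3ccccc3)cc2C(=O)/C=C\Nc2ccc(Cl)cc2)cc1` is the next member: relative to compound 2 the change is chloro in place of fluoro on an aromatic carbon. Among the measured compounds shown here, no measured pair isolates this exact change, so nothing in the numbers fixes its size or direction. The working expectation is a step from compound 2 to compound 3 that stays within the scatter, a 1.1-fold higher number from compound 2 to compound 3 (0.05 log units; within the scatter). On that basis compound 3 is estimated at 4500 nM in this assay, with a range from 1800 nM to 11000 nM.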

Compound 3, half-maximal inhibitory concentration: 2970 nM
The estimate for compound 3 lay 1.5-fold (0.18 log units) above the measured number; the measured number falls inside the stated range.
By their numbers in this assay, from the lowest: compounds 3, 2 and 1 (each within the scatter of the next, the first and the last beyond it).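

Among the compounds shown here, at the (4-fluorophenyl)amino to (4-chlorophenyl)amino exchange, on an aromatic carbon para to a large group, the methoxy-substituted aryl stays fixed and this assay shows a 1.3-fold lower number from compound 2 to compound 3 (0.13 log units; within the scatter), so this exchange of one halogen for the other gives the first single-place reading at this position and no order can be drawn from it. For the compounds shown here, the new member also supplies the first step that lies beyond the scatter: with the (4-chlorophenyl)amino group held, methoxy in place of fluoro on the other aryl gives a 2.3-fold lower number from compound 1 to compound 3 (0.35 log units; beyond the scatter), a modest change that the earlier pair, differing in two places, could not isolate. No supporting measurement bears on the size of either step.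

On these data alone, each of the two changes is seen in a single setting, so it remains open whether the halogen exchange reads the same with the fluoro-substituted aryl and whether the methoxy step holds with the (4-fluorophenyl)amino group. Only fluoro and chloro occupy the anilino position here, which leaves open how a methoxy, an amine or a carboxylic acid at that place would read.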